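The source may hold more compounds than are shown below. What is called first, only, known or untested is meant among the compounds shown, and "the series" means these compounds.

Measured in an ADME assay on the whole organism for pharmacokinetics, with Rattus norvegicus as the target; a higher number here means faster removal of the compound, a lower number slower removal:
- compound 1 `CC(C)OC[C@H](Oc1ncnc2c1cnn2-c1ncccc1Cl)C(=O)Nc1ccc(Cl)cn1`: 120 mL/min/kg
- compound 2 `CC(C)OC[C@H](Oc1ncnc2c1cnn2-c1ncccc1Cl)C(=O)Nc1ccc(F)cn1`: 600 mL/min/kg

Of these two, compound 2 stands highest, and compound 1 is its nearest neighbour. Compound 3 `CC(C)OC[C@H](Oc1ncnc2c1cnn2-c1ncccc1Cl)C(=O)Nc1ccc(C#N)cn1` has not yet been measured. It differs from compound 2 at one place: cyano in place of fluoro on an aromatic carbon. This puts cyano in place of fluoro on an aromatic carbon, two atoms from the ring nitrogen and para to a large group.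

Among the measured compounds shown here, only one measured step bears on this carbon. With fluoro in place of chloro, the change is a 5.0-fold higher number from compound 1 to compound 2 (0.70 log units; beyond the scatter). This modest step shows that a swap at this carbon can move clearance beyond the scatter. For the measured compounds named here, no compound with a cyano group has been measured, however, so its size carries over only loosely. The direction is also an expectation rather than a finding, and it rests on compound 2 being the higher of the two at 600 mL/min/kg.

The expected change in this assay is a 2.5-fold lower number from compound 2 to compound 3 (0.40 log units; beyond the scatter), a modest step downward. For compound 3 the estimated clearance is 240 mL/min/kg, with an expected range of 90 mL/min/kg to 600 mL/min/kg.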

Compound 3, clearance in the Rattus norvegicus assay: 81 mL/min/kg
Estimate against measurement, compound 3: 3.0-fold (0.47 log units) above; the measured number lies below the stated range.
By their numbers in the Rattus norvegicus assay, from the lowest: compounds 3 and 1 (each within the scatter of the next); then compound 2.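

In the Rattus norvegicus assay, this carbon can carry a group quite unlike chloro and still land with compound 1, as cyano in place of chloro gives a 1.5-fold lower number from compound 1 to compound 3 (0.17 log units; within the scatter). Cyano in place of fluoro gives a 7.4-fold lower number from compound 2 to compound 3 (0.87 log units; beyond the scatter) in the Rattus norvegicus assay, so the earlier step, a 5.0-fold higher number from compound 1 to compound 2 (0.70 log units; beyond the scatter), now looks less like a general sensitivity to change at this carbon and more like fluoro standing apart from two groups that this assay cannot tell apart. In a physicochemical assay for pharmacokinetics, at pH 6 (a lower number here means that the compound disappears faster, a higher number that the compound lasts longer), compound 2 gives > 552 h, which is a limit of the assay and not a number. In the physicochemical assay compound 3 gives > 552 h, which is likewise a limit of the assay and not a number. In the physicochemical assay the step between these two fluoro and cyano compounds cannot be read, and that assay adds nothing on this change, since both results are limits rather than numbers: the limit of > 552 h in the physicochemical assay, at which 2 of the 2 values shown sit.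

From the compounds shown here alone, three groups at one carbon are a small sample, so it remains open whether a methyl group, a methoxy group or a plain hydrogen would sit with chloro and cyano or with fluoro. The compounds shown also do not tell why compound 2 is removed so much faster, or whether the same gap would appear if another part of the molecule were changed.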